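The source may hold more compounds than are shown below. What is called first, only, known or untested is meant among the compounds shown, and "the series" means these compounds.

In an in vitro ADME assay on microsomes from liver (Homo sapiens) for metabolic stability, in the presence of a further agent that is not named here (a higher number here means faster removal of the compound, a lower number slower removal), compound 1 `COc1ccc(C)cc1Cn1c(C(=O)NCC(C)(C)CO)cc2cc(C#N)ccc21` gives 23 mL.min-1.g-1 and compound 2 `Cc1ccc(Cl)cc1Cn1c(C(=O)NCC(C)(C)CO)cc2cc(C#N)ccc21` gives 23 mL.min-1.g-1, so compound 2 stands level with compound 1. Compound 3 `CCCOc1cccc(Cn2c(C(=O)NCC(C)(C)CO)cc3cc(C#N)ccc32)c1` has not been measured yet. It keeps the shared core, but 3-propoxyphenyl takes the place of 5-chloro-2-methylphenyl on a saturated chain carbon bound to an aromatic nitrogen: 3-propoxyphenyl in place of 5-chloro-2-methylphenyl on a saturated chain carbon bound to an aromatic nitrogen.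

Within the data shown here, only one measured step bears on this change. It was made at the same place, and its size, no change at the digits printed from compound 1 to compound 2 (within the scatter), lies within the scatter. Among the measured compounds shown here, that step involved different groups, and no measured compound carries a propoxy group, so it is only a weak guide. No step beyond the scatter is therefore expected in this assay. The estimated change is a 1.2-fold higher number from compound 2 to compound 3 (0.09 log units; within the scatter). Compound 3 is expected at 28 mL.min-1.g-1, with an estimated range from 12 mL.min-1.g-1 to 60 mL.min-1.g-1.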

Compound 3, intrinsic clearance in microsomes: 10 mL.min-1.g-1
For compound 3 the middle estimate is 2.8-fold (0.45 log units) above the measured one; the whole stated range lies above it.
By their numbers in this assay, from the lowest: compound 3; then compounds 1 and 2 (each within the scatter of the next).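

In this assay, this position on a saturated chain carbon bound to an aromatic nitrogen proves able to shift the read-out, which the earlier exchange, no change at the digits printed from compound 1 to compound 2 (within the scatter), did not show. The 3-propoxyphenyl group gives a 2.3-fold lower number from compound 2 to compound 3 (0.36 log units; beyond the scatter), and the same group gives a 2.3-fold lower number from compound 1 to compound 3 (0.36 log units; beyond the scatter), so both comparisons point to slower removal, though only modestly. Nothing measured here explains this drop.

The change replaces the whole aryl group at once, so these compounds cannot separate the effect of the propoxy chain from that of the other differences between the groups. On these data alone, it also remains open whether a shorter chain, as in 3-ethoxyphenyl, or a longer one, as in 3-butoxyphenyl, would keep, enlarge or lose this step.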